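Aryl swap on the ring nitrogen: compound 3 to 4

The source may report more compounds than this note shows. Statements on the series, on what has been measured and on what is new or still open speak of the compounds shown alone.

In a functional assay on SGC-7901 cells (Homo sapiens) for antiproliferative activity, read by MTT assay, with a stated time of 24 h (a higher number here means a weaker inhibitor, a lower number a stronger inhibitor), compound 3 `Cc1ccc(-n2cc(-c3ccccc3NS(=O)(=O)c3c[nH]c(=O)[nH]c3=O)nn2)cc1` gives 6390 nM. Its neighbours are compound 2 `Cc1cccc(-n2cc(-c3ccccc3NS(=O)(=O)c3c[nH]c(=O)[nH]c3=O)nn2)c1` with 3510 nM and compound 1 `O=c1[nH]cc(S(=O)(=O)Nc2ccccc2-c2cn(-c3ccccc3)nn2)c(=O)[nH]1` with 11800 nM; compound 3 stands second highest of the three, yet a 1.8-fold higher number from compound 2 to compound 3 (0.26 log units; within the scatter) and a 1.8-fold lower number from compound 1 to compound 3 (0.27 log units; within the scatter) both sit within the scatter, so no order among these three can be read. Only a 3.4-fold lower number from compound 1 to compound 2 (0.53 log units; beyond the scatter) reaches beyond it.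

Compound 4 `O=c1[nH]cc(S(=O)(=O)Nc2ccccc2-c2cn(-c3cccc(F)c3)nn2)c(=O)[nH]1` carries 3-fluorophenyl in place of 4-methylphenyl on an aromatic nitrogen. For the measured compounds named here, the steps that bear on this are the move of the methyl between ring positions, a 1.8-fold higher number from compound 2 to compound 3 (0.26 log units; within the scatter), and the two methyl additions, a 3.4-fold lower number from compound 1 to compound 2 (0.53 log units; beyond the scatter) and a 1.8-fold lower number from compound 1 to compound 3 (0.27 log units; within the scatter). Going by these compounds, none of them involves a fluorine, so the swap of methyl for fluorine itself is untested. The spread across compounds 1 to 3 is narrow, and the change is expected to give a 1.1-fold lower number from compound 3 to compound 4 (0.03 log units; within the scatter), no step beyond the scatter. Compound 4 is accordingly estimated at 6000 nM, with a range from 2500 nM to 14000 nM.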

Compound 4, half-maximal inhibitory concentration: > 20000 nM
Compound 4: only a limit was reported; the forecaster's own chance of this, stated with the estimate: 5%; middle value at least 3.3-fold (0.52 log units) from the limit.
By their numbers in this assay, from the lowest: compounds 2, 3 and 1 (each within the scatter of the next, the first and the last beyond it). At a limit, above all of these: compound 4.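

In this assay compound 4 reads only as a limit, not as a number: the limit of > 20000 nM in this assay, at which 1 of the 4 values shown sits.

Even so, this position on the aryl group proves sensitive to the substituent: fluoro in place of methyl gives an at least 5.6-fold higher number from compound 2 to compound 4 (0.75 log units; beyond the scatter), and the full aryl swap gives an at least 3.1-fold higher number from compound 3 to compound 4 (0.49 log units; beyond the scatter), whereas moving the methyl between ring positions stayed within the scatter. The step for fluoro in place of hydrogen, an at least 1.6-fold higher number from compound 1 to compound 4 (0.22 log units; that floor lies within the scatter), shows no change that can be read.

Open, going by these compounds, is whether a chlorine or a methoxy group in the place of the fluoro would follow compound 4 or compound 2. Also open, on these data alone, is whether the fluoro group would give the same result at the ring position of the methyl in compound 3.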